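This account rests on a few compounds, and the source may have more. Where it says the series, first, only, none or still open, it means among the compounds named here.

Measured compounds:
- compound 1 `Clc1ccc(CO/N=C/c2c(-c3ccc4ccccc4c3)nc3occn23)cc1Cl` — 370 nM
- compound 2 `Clc1ccc(CO/N=C/c2c(-c3cccc4ccccc34)nc3sccn23)cc1Cl` — 940 nM
- compound 3 `Clc1ccc(-c2nc3occn3c2/C=N/OCc2ccc(Cl)c(Cl)c2)cc1` — 410 nM

In an assay on HepG2 cells for agonist activity at nuclear receptor subfamily 1 group I member 3 (Homo sapiens), read by a luciferase reporter, with a stated time of 23 h (on this read-out lower numbers stand for an effect already at smaller amounts and higher numbers for an effect only at larger amounts of compound), compound 1 sits at the lower end of the three numbers shown. Compound 3 lies so close that the two cannot be told apart, as the step of a 1.1-fold higher number from compound 1 to compound 3 (0.04 log units; within the scatter) shows; compound 2 stands further off, beyond the scatter.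

Compound 4 `Clc1ccccc1CO/N=C/c1c(-c2ccc3ccccc3c2)nc2occn12` has not been measured. It differs from compound 1 in one place: 2-chlorophenyl in place of 3,4-dichlorophenyl on a saturated chain carbon bound to an oxygen on an unsaturated carbon. One chlorine is removed and the remaining one sits in a different position on the ring.

Among the compounds with values here, none of the measured steps touches this part of the molecule. Within the data shown here, the only step measured, from compound 1 to compound 3, changes a different ring and is within the scatter, so it says nothing about the benzyl group. With no direct guide, a modest shift to a higher number is expected, a 1.9-fold higher number from compound 1 to compound 4 (0.28 log units; within the scatter), but the uncertainty is wide. Compound 4 is therefore estimated at 700 nM in this assay, with a range from 250 nM to 2500 nM.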

Compound 4, half-maximal effective concentration: 1100 nM
Estimate against measurement, compound 4: 1.6-fold (0.20 log units) below, and the stated range covers the measured number.
By their numbers in this assay, from the lowest: compounds 1 and 3 (each within the scatter of the next); then compounds 2 and 4 (each within the scatter of the next).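

In this assay, replacing 3,4-dichlorophenyl with 2-chlorophenyl on the saturated chain carbon gives a 3.0-fold higher number from compound 1 to compound 4 (0.47 log units; beyond the scatter) and so moves the number beyond the usual scatter. Within the data shown here, the earlier step of a 1.1-fold higher number from compound 1 to compound 3 (0.04 log units; within the scatter) changed a different part of the molecule and stayed within the scatter, so this is the first sign that the read-out responds to a change in the benzyl group. Two things change at once here, the number of chlorines and where the chlorine sits, and nothing measured explains the shift or separates these two changes.

The compounds shown leave open how plain phenyl, with no chlorine, would compare on this carbon. They also leave open what a nitrile on the phenyl ring, or a longer chain between the oxygen and that ring, would do.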